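Compound 4 and the Hydroxymethyl Step

The compounds below may be only part of what the source reports. "The series", "measured", "known", "first", "only" and "open" are said of these compounds alone.

Compound 1 `CCOCc1c(C)coc1-c1ccc2c(c1OC)CCCC2(C)C` gives 19.8 uM
Compound 2 `COC(=O)c1c(C)coc1-c1ccc2c(c1OC)CCCC2(C)C` gives 27.1 uM
Compound 3 `COCc1c(C)coc1-c1ccc2c(c1OC)CCCC2(C)C` gives 18.5 uM

These three compounds were tested in a functional assay on SK-BR-3 cells (Homo sapiens) for cytotoxicity, read by sulforhodamine B assay, with a stated time of 3 days; on this read-out lower numbers stand for an effect already at smaller amounts and higher numbers for an effect only at larger amounts of compound. Compound 3 stands within the scatter of both compound 1 and compound 2, so the three numbers form a single level and have no meaningful order.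

The next compound is compound 4 `COc1c(-c2occ(C)c2CO)ccc2c1CCCC2(C)C`, which differs from compound 3 at one place (hydrogen in place of methyl on an oxygen on a saturated carbon). Methoxymethyl becomes hydroxymethyl.

The closest measured step also removes a methyl, though on a saturated chain carbon bound to an oxygen: a 1.1-fold lower number from compound 1 to compound 3 (0.03 log units; within the scatter). The two other steps exchange groups on an aromatic carbon: a 1.4-fold higher number from compound 1 to compound 2 (0.14 log units; within the scatter) and a 1.5-fold lower number from compound 2 to compound 3 (0.17 log units; within the scatter). All three stay within the scatter. However, no measured compound carries a hydroxymethyl group, so the data do not test this change directly, and the range must stay wide.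

On this evidence, no shift beyond the scatter is expected in this assay, and no direction can be favoured. The expected step is a 1.1-fold higher number from compound 3 to compound 4 (0.03 log units; within the scatter). For compound 4 the estimated value is 20 uM, within an expected range from 9 uM to 42 uM.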

Compound 4, concentration for half-maximal effect: 23.7 uM
Beside the measured number, compound 4's estimate is 1.2-fold (0.07 log units) below it; low and high end bracket the measured number.
By their numbers in this assay, from the lowest: compounds 3, 1, 4 and 2 (each within the scatter of the next).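

In this assay, the methyl on the oxygen of the methoxymethyl group gives way to hydrogen with a 1.3-fold higher number from compound 3 to compound 4 (0.11 log units; within the scatter), so a hydroxymethyl group, the first in this set with no alkyl group on that oxygen, stays on the same level as its methyl ether. The steps from the other two compounds read the same way, with a 1.2-fold higher number from compound 1 to compound 4 (0.08 log units; within the scatter) for the replacement of ethyl by hydrogen on that oxygen and a 1.1-fold lower number from compound 2 to compound 4 (0.06 log units; within the scatter) for hydroxymethyl in place of methoxycarbonyl on the aromatic carbon, which places ethoxymethyl, methoxymethyl, hydroxymethyl and methoxycarbonyl together on a single level at this position. Nothing in the material shown accounts for this flat result.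

The compounds shown leave open whether an aminomethyl group, a carboxylic acid or a longer chain such as butoxymethyl on that aromatic carbon would move the number beyond the scatter of these four. They also leave open whether the same level would hold with the shared core changed elsewhere, since all four compounds differ only at this one place.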